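The source may report more compounds than this note shows. Statements on the series, on what has been measured and on what is new or still open speak of the compounds shown alone.

Compound 1 `CC[C@H]1CN(c2ncc(C(=O)NC)nc2C(F)(F)F)CCN1C1CCN(C(=O)c2ccc(Cl)nc2N)CC1` is measured in an in vitro assay on BaF3 cells for displacement of a labelled ligand from C-X-C chemokine receptor type 3 (Homo sapiens) (on this read-out lower numbers stand for stronger inhibition and higher numbers for weaker inhibition), where compound 1 gives 1.5 nM. Compound 2 `CC[C@H]1CN(c2ncc(C(=O)NC3CC3)nc2C(F)(F)F)CCN1C1CCN(C(=O)c2ccc(Cl)nc2N)CC1` carries the change (cyclopropyl in place of methyl on an amide-type nitrogen), and in this assay compound 2 gives 1.8 nM, a step of a 1.2-fold higher number from compound 1 to compound 2 (0.08 log units; within the scatter). Compound 3 `CC[C@H]1CN(c2ncc(C(=O)NC)nc2C)CCN1C1CCN(C(=O)c2ccc(Cl)cc2)CC1` has a different core; how its core differs from that of compound 1 is not broken down here. In this assay compound 3 gives 3.6 nM. Compound 4 `CC[C@H]1CN(c2ncc(C(=O)NC3CC3)nc2C)CCN1C1CCN(C(=O)c2ccc(Cl)cc2)CC1` is not yet measured and differs from compound 3 by cyclopropyl in place of methyl on an amide-type nitrogen, the same change as from compound 1 to compound 2, at the same place. On the strength of that one step, compound 4 is expected to show a step of a 1.2-fold higher number from compound 3 to compound 4 (0.08 log units; within the scatter) in this assay. Compound 4 is therefore estimated at 4.3 nM, likely between 2 nM and 9 nM.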

Compound 4, half-maximal inhibitory concentration: 1.1 nM
For compound 4 the middle estimate is 3.9-fold (0.59 log units) above the measured one, and the stated range ends above it.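

In this assay, cyclopropyl in place of methyl on the amide-type nitrogen gives a 3.3-fold lower number from compound 3 to compound 4 (0.51 log units; beyond the scatter), and this step does not match the one seen on the core of compound 1: the same change on two cores in this assay, a 1.2-fold higher number (0.08 log units; within the scatter) from compound 1 to compound 2 and a 3.3-fold lower number (0.51 log units; beyond the scatter) from compound 3 to compound 4, 3.9-fold (0.59 log units) apart, beyond the scatter of two such steps. In this series, then, the step measured on one core was a poor guide to the same change on the other. The two cores differ in more than one place, and these two pairs do not show which of those differences matters or how the change would behave on any further core.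

From the compounds shown here alone, it remains open how an ethyl or cyclobutyl group on that nitrogen would behave on each core. Also open, going by these compounds, is which step a core differing from that of compound 1 in only one place would follow.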